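Adding a Bromine to a Phenolic Chalcone

The compounds below may be only part of what the source reports. "The series", "measured", "known", "first", "only" and "open" are said of these compounds alone.

Of the compounds shown here, two have been measured in an assay on isolated protein for inhibition of protein arginine N-methyltransferase 1 (Homo sapiens), tested at 50 uM; a lower number here means less inhibition, a higher number more inhibition at the concentration tested (going by the name of the read-out). Compound 1, `O=C(/C=C/c1ccc(O)c(Br)c1)/C=C/c1cc(Br)c(O)c(Br)c1`, carries two bromine-bearing phenol rings joined through a dienone; in this assay compound 1 gives 17%. Compound 2, `O=C(/C=C/c1ccc(O)c(Br)c1)c1cc(Br)c(O)c(Br)c1`, keeps both rings but links one of them directly to the carbonyl; in this assay compound 2 gives 36%. Compound 2 thus stands highest of the two numbers, and its nearest neighbour, compound 1, lies a number lower by an amount beyond the usual scatter, so the two are genuinely distinct.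

Compound 3, `O=C(/C=C/c1cc(Br)c(O)c(Br)c1)c1cc(Br)c(O)c(Br)c1`, has not yet been measured. Compared with compound 2, the change is bromo in place of hydrogen on an aromatic carbon, so that both rings of compound 3 now carry two bromines. Among the compounds with values here, no measured pair in this set isolates such an addition, so the size of its effect is unknown. Compound 3 is expected to change by about a number 6 percentage points higher from compound 2 to compound 3 (within the scatter), a step that is small and within the scatter. Compound 3 is estimated to give 42%, with a likely range from 25% to 60%.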

Compound 3, a percentage reported as inhibition, at one concentration (the size of the read-out at that concentration, not a potency): 61%
Beside the measured number, compound 3's estimate is 19 percentage points below it, outside the stated range (above it).
By their numbers in this assay, from the lowest: compound 1; then compound 2; then compound 3.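

In this assay, within the data shown here, bromo in place of hydrogen on an aromatic carbon, ortho to a hydroxy group, gives a number 25 percentage points higher from compound 2 to compound 3 (beyond the scatter) and provides the first comparison in this set in which only one place changes. It shows that this position is not indifferent to substitution: a single added heavy atom, with no hydrogen-bond donors, no hydrogen-bond acceptors and no net charge, is enough to raise inhibition at the tested concentration by more than the usual scatter. Nothing available here explains why this one bromine raises the read-out.

Going by these compounds, whether the gain needs bromine in particular stays open, since a chloro or methyl group on the same carbon would be needed to separate bromine from other small groups, and a methoxy group in place of the neighbouring hydroxy group would test whether that hydroxy group matters to the result. This single pair also leaves open whether the same swap would give a similar rise on another scaffold, and, as the read-out is taken at one concentration, it gives no potency.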